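Replacing pentan-3-yl in compound 2: expected clearance

The compounds below may be only part of what the source reports. "The series", "measured", "known", "first", "only" and "open" are said of these compounds alone.

Of the compounds shown here, two so far have a reading in an ADME assay on microsomes from liver (Homo sapiens) for metabolic stability; on this read-out higher numbers stand for fast clearance and lower numbers for slow clearance. Compound 1 (`COc1cnc(-c2cc(Oc3ccc(S(C)(=O)=O)cc3)cc(OC(C)C)c2)[nH]c1=O`) gives < 8 mL/min/kg, which is a limit of the assay and not a number. Going by the values given here, compound 2 (`CCC(CC)Oc1cc(Oc2cnc(C(=O)N(C)C)nc2)cc(-c2nccc(=O)[nH]2)c1`) gives 22.4 mL/min/kg, the only true number available, so its standing cannot yet be set against any other measured figure.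

Compound 3 (`C[C@@H](CO)Oc1cc(Oc2cnc(C(=O)N(C)C)nc2)cc(-c2nccc(=O)[nH]2)c1`) keeps the rest of compound 2 and differs in one place: 1-(hydroxymethyl)ethyl in place of pentan-3-yl on an oxygen on an aromatic ring. Among the compounds with values here, no measured step calibrates this change, so the expectation rests on the structural change alone. A step towards slower clearance in this assay is expected, somewhat beyond the usual scatter. The expected step is a 2.2-fold lower number from compound 2 to compound 3 (0.35 log units; beyond the scatter). Compound 3 is estimated at 10 mL/min/kg, with an expected range of 6 mL/min/kg to 18 mL/min/kg.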

Compound 3, clearance in the Homo sapiens assay: < 8 mL/min/kg
Compound 3: a limit, no number; the forecaster's own chance of this, stated with the estimate: 40%; middle value at least 1.2-fold (0.09 log units) from the limit.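

In the Homo sapiens assay, compound 2 gives 22.4 mL/min/kg. In the Homo sapiens assay, compound 3 gives < 8 mL/min/kg, which is a limit of the assay and not a number. Going by these compounds alone, in the Homo sapiens assay, 1-(hydroxymethyl)ethyl in place of pentan-3-yl on an oxygen on an aromatic ring gives the first calibrated step at this position: an at least 2.8-fold lower number from compound 2 to compound 3 (0.44 log units; beyond the scatter). The step is bounded from one side only, since the reading for compound 3 is a limit of the assay and not a number: the limit of < 8 mL/min/kg in the Homo sapiens assay, at which 2 of the 3 values shown sit. In a physicochemical assay for solubility, in phosphate buffer, measured as kinetic solubility, with a stated time of 24 h, at pH 6.5 (a lower number here means a less soluble compound, a higher number a more soluble compound), compound 2 gives 469000 nM and compound 3 gives 339000 nM. In the physicochemical assay, the same change gives a 1.4-fold lower number from compound 2 to compound 3 (0.14 log units; within the scatter), so this pair shows a clearance step beyond the scatter without a solubility step beyond it.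

The pair cannot separate the hydroxyl from the shorter chain or from the defined stereocentre, as all three enter together. As far as these compounds go, how clearance would respond to an amine, a carboxylic acid or a methoxyethyl chain on the same oxygen also stays open.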